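The source may hold more compounds than are shown below. What is called first, only, known or untested is meant among the compounds shown, and "the series" means these compounds.

Three measured compounds share one core: compound 1 `CN(C)CCCOc1ccc(CN(C)c2nc3ccc(Oc4ccc(C(F)(F)F)cc4)cc3s2)cc1`, compound 2 `CN(Cc1ccc(OCCCNC(=N)N)cc1)c1nc2ccc(Oc3ccccc3)cc2s1` and compound 3 `CN(Cc1ccc(OCCCNC(=N)N)cc1)c1nc2ccc(Oc3ccc(C(F)(F)F)cc3)cc2s1`. In an assay on cells for inhibition of Voltage-dependent T-type calcium channel subunit alpha-1H (Homo sapiens), read by FLIPR and calcium flux, with stated times of 600 s and 300 s (on this read-out lower numbers stand for stronger inhibition and higher numbers for weaker inhibition), compound 1 gives 54000 nM, compound 2 gives 498000 nM and compound 3 gives 212000 nM. Compound 3 therefore stands second highest of the three numbers; its nearest neighbour is compound 2 and the furthest is compound 1. Two steps connect these numbers. Along one, a 3.9-fold higher number from compound 1 to compound 3 (0.59 log units; beyond the scatter). Along the other, a 2.3-fold lower number from compound 2 to compound 3 (0.37 log units; beyond the scatter).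

Compound 4 `CN(Cc1ccc(OCCCNC(=N)N)cc1)c1nc2ccc(Oc3cccc(C(F)(F)F)c3)cc2s1` holds the same atoms as compound 3 joined differently: 3-(trifluoromethyl)phenyl in place of 4-(trifluoromethyl)phenyl on an oxygen on an aromatic ring. Within the data shown here, no measured step moves a group from one place on a ring to another, so none bears directly on this change. The nearest relative is a 2.3-fold lower number from compound 2 to compound 3 (0.37 log units; beyond the scatter), which shows that the trifluoromethyl itself is worth a modest step on this read-out. Shifting it might keep part of that gain or give it back, so in this assay a step of no more than modest size is expected, with no clear direction, and most likely within the scatter.

For compound 4 the estimate in this assay is 260000 nM, with a range from 100000 nM to 650000 nM. The step this implies, a 1.2-fold higher number from compound 3 to compound 4 (0.09 log units; within the scatter), is the expected one.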

Compound 4, half-maximal inhibitory concentration: 771000 nM
For compound 4 the middle estimate is 3.0-fold (0.47 log units) below the measured one, outside the stated range (above it).
By their numbers in this assay, from the lowest: compound 1; then compound 3; then compounds 2 and 4 (each within the scatter of the next).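

In this assay, among these compounds, the place of the trifluoromethyl on the outer phenyl ring matters: 3-(trifluoromethyl)phenyl in place of 4-(trifluoromethyl)phenyl gives a 3.6-fold higher number from compound 3 to compound 4 (0.56 log units; beyond the scatter), a step of modest size that the earlier compounds could not reveal. Set against the compound without the group, this placement gives a 1.5-fold higher number from compound 2 to compound 4 (0.19 log units; within the scatter), whereas the other placement gave a 2.3-fold lower number from compound 2 to compound 3 (0.37 log units; beyond the scatter), so among these compounds the gain from adding trifluoromethyl appears only with 4-(trifluoromethyl)phenyl and is not a property of the group wherever it sits. Nothing measured here explains why the two placements differ.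

The compounds shown leave open whether a chlorine atom or a methoxy group would show the same dependence on place, since trifluoromethyl is the only group on this ring compared at these two places. Among the compounds shown here, they also leave open whether moving the trifluoromethyl would count for as much with the dimethylamino chain end of compound 1, as the move is seen only with the chain end shared by compound 3 and compound 4.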